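Ester-to-acrylate change on the shared core

The compounds below may be only part of what the source reports. "The series", "measured", "known", "first", "only" and "open" are said of these compounds alone.

Three measured compounds share one core. Compound 1 `CCOC(=O)c1ccc(-c2nn(Cc3ccc(Cl)cc3)c3ccccc23)cc1` carries an ethyl ester; in a functional assay on cells (Platelet, Homo sapiens) for inhibition (on this read-out higher numbers stand for weaker inhibition and lower numbers for stronger inhibition), compound 1 gives > 10000 nM, which is a limit of the assay and not a number. Compound 2 `CCOC(=O)c1ccc(-c2nn(-c3ccco3)c3ccccc23)cc1` differs at the aromatic nitrogen; in this assay compound 2 gives > 10000 nM, also a limit. The step that the two limits leave unreadable from compound 1 to compound 2 therefore cannot be read. Compound 3 `CC(C)OC(=O)c1ccc(-c2nn(Cc3ccccc3)c3ccccc23)cc1` carries the isopropyl ester; in this assay compound 3 gives > 10000 nM, again a limit. Compound 3 thus stands where the other two stand, at the limit of > 10000 nM in this assay, at which 3 of the 3 values shown sit, and no measured value sits anywhere else.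

Compound 4 `CCOC(=O)/C=C/c1ccc(-c2nn(Cc3ccccc3)c3ccccc23)cc1` is the next member. The change is 2-(ethoxycarbonyl)ethenyl in place of isopropoxycarbonyl on an aromatic carbon. Within the data shown here, no measured step touches this position; the single readable pair concerns the aromatic nitrogen and is itself unreadable. With every shown value at the limit, compound 4 is expected to give 15000 nM, with a range from 5000 nM to 50000 nM. The step that the limit leaves unreadable from compound 3 to compound 4 is accordingly expected to be none beyond the scatter, most likely another limit.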

Compound 4, half-maximal inhibitory concentration: > 10000 nM
Compound 4: only a limit was reported (the forecaster's own chance of this, stated with the estimate: 80%); the middle value is on the limit's open side.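

No step can be read from compound 3 to compound 4, since both results are limits and not numbers: the limit of > 10000 nM in this assay, at which 4 of the 4 values shown sit.

The compounds shown leave open whether any change on the shared core brings a readable value in this assay, and how large any step between them is.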